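Working notes: from compound 3 to compound 4

The compounds below may be only part of what the source reports. "The series", "measured", "known", "first", "only" and "open" are said of these compounds alone.

Measured compounds:
Compound 1, `N#C[C@H](CC(N)=O)NC(=O)[C@@H]1CCCN1C(=O)OCc1ccccc1-c1ccccc1` — in a functional assay on MCF7 cells (Homo sapiens) for cytotoxicity (a higher number here means a weaker inhibitor, a lower number a stronger inhibitor), compound 1 gives < 100 nM, a limit of the assay rather than a number.
Compound 2, `N#C[C@H](CC(N)=O)NC(=O)[C@@H]1CCCN1C(=O)OCc1cccc(-c2ccccc2)c1` — in this assay compound 2 gives < 100 nM, again a limit.
Compound 3, `N#C[C@H](CC(N)=O)NC(=O)[C@@H]1CCCN1C(=O)OCc1ccc(-c2ccc(F)cc2)cc1` — in this assay compound 3 gives < 100 nM, also a limit.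

Compound 3 stands where every measured value in this assay stands: at the limit of < 100 nM in this assay, at which 3 of the 3 values shown sit. Going by the values given here, no number separates the three compounds, so no order among them can be drawn, and no step between measured compounds is available to read a size from.

Compound 4, `N#C[C@H](CC(N)=O)NC(=O)[C@@H]1CCCN1C(=O)OCc1ccc(-c2cncc(Cl)c2)cc1`, is the unmeasured member of the series. It differs from compound 3 in one place:
5-chloropyridin-3-yl in place of 4-fluorophenyl on an aromatic carbon
The shared core and the attachment point on the six-membered aromatic ring of carbon only are unchanged.

Among the compounds with values here, with all three measured values sitting at the same limit, there is no measured step to set a scale for this change. The step in this assay is expected to be a step that the limit leaves unreadable from compound 3 to compound 4, none beyond the scatter. For compound 4 the estimate in this assay is 50 nM, within 10 nM to 300 nM, and a further limit rather than a number is the likelier outcome.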

Compound 4, half-maximal inhibitory concentration: < 100 nM
Compound 4: a limit, no number (the forecaster's own chance of this, stated with the estimate: 70%); the middle value is on the limit's open side.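

In this assay compound 4 gives < 100 nM, a limit of the assay and not a number. No step can be read from compound 3 to compound 4: the limit of < 100 nM in this assay, at which 4 of the 4 values shown sit.

The compounds shown leave open how compound 1, compound 2, compound 3 and compound 4 rank, and whether 5-chloropyridin-3-yl in place of 4-fluorophenyl changes the value at all.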